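Swapping ethynyl for furan-3-yl on a weak methylamino analogue

This account rests on a few compounds, and the source may have more. Where it says the series, first, only, none or still open, it means among the compounds named here.

Measured so far:
- compound 1 `C#Cc1cn([C@@H]2O[C@H](CO)[C@@H](O)[C@H]2O)c2ncnc(C)c12`: 290 nM
- compound 2 `C#Cc1cn([C@@H]2O[C@H](CO)[C@@H](O)[C@H]2O)c2ncnc(NC)c12`: > 15000 nM

Compound 1 and compound 2 share a core and differ only where a methylamino in place of methyl on an aromatic carbon has been made. In a functional assay on HepG2 cells (Homo sapiens) for antiproliferative activity, read by XTT assay, with a stated time of 72 h (a higher number here means a weaker inhibitor, a lower number a stronger inhibitor), compound 1 gives 290 nM. For compound 2 this assay reports only a limit, > 15000 nM, so compound 2 stands at the weak end of the two values shown. The step of an at least 51-fold higher number from compound 1 to compound 2 (1.71 log units; beyond the scatter) is large, since one of the two values sits at the limit of > 15000 nM in this assay, at which 1 of the 2 values shown sits.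

Compound 3 `CNc1ncnc2c1c(-c1ccoc1)cn2[C@@H]1O[C@H](CO)[C@@H](O)[C@H]1O` is not yet measured. It differs from compound 2 by furan-3-yl in place of ethynyl on an aromatic carbon. Among the compounds with values here, no measured step touches the ethynyl position, so nothing among the measured pairs bears on this change; the only guide is the limit of compound 2 itself. A step of a number no higher from compound 2 to compound 3 (the limit leaves the size open) is expected, meaning no clear shift beyond the scatter. Compound 3 is therefore estimated at 15000 nM, between 3000 nM and 60000 nM, with a real chance that this assay again returns only a limit.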

Compound 3, half-maximal inhibitory concentration: > 20000 nM
Compound 3: no number, only a limit; the forecaster's own chance of this, stated with the estimate: 60%; at least 1.3-fold (0.12 log units) between middle value and limit.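

In this assay compound 3 gives only a limit, > 20000 nM, and compound 2 also gives only a limit, so the step between compound 2 and compound 3 cannot be read. The compounds shown leave open whether furan-3-yl in place of ethynyl changes the activity at all.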